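Adding oxygen at the sulfur of compound 2

A few compounds are considered here, and "the series" means these few. Any claim that something is new, unique, unknown or untested is made for them only; others in the source may bear on it.

In a functional assay on the whole organism for antagonist activity, with Mus musculus as the target (a higher number here means that more compound is needed for the effect, a lower number that less compound is needed), compound 2 `CSc1nc(-c2ccccc2)n(C)n1` gives > 100 mg/kg, a limit of the assay and not a number. Compound 3 `Cn1nc([S+](C)[O-])nc1-c1ccccc1` differs from it at the methylsulfanyl group, on an aromatic carbon: a group of 3 heavy atoms (1 carbon, 1 oxygen, 1 sulfur; no ring) in place of a group of 2 heavy atoms (1 carbon, 1 sulfur; no ring), on an aromatic carbon. Compound 1 `COc1ccc(-c2nnc([S+](C)[O-])n2C)cc1` already carries the entering group and gives > 100 mg/kg, also a limit. Within the data shown here, the evidence so far is the limit of > 100 mg/kg in this assay, at which 2 of the 2 values shown sit, and no measured step is available. The estimated at least 1.2-fold lower number from compound 2 to compound 3 (0.09 log units; that floor lies within the scatter) is expected to be small, towards less compound needed, and another limit remains likely. For compound 3 the estimated value is 80 mg/kg, with an expected range of 25 mg/kg to 200 mg/kg.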

Compound 3, dose for half-maximal effect: > 200 mg/kg
Compound 3: no number, only a limit; the forecaster's own chance of this, stated with the estimate: 55%; middle value at least 2.5-fold (0.39 log units) from the limit.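

Compound 2 and compound 3 both stand at limits in this assay, so no step can be read between them. The compounds shown leave open what number either compound would give, and so the size and direction of this change.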